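Cytotoxicity Limits Along a Shared Oxazolidinone Series

A few compounds are considered here, and "the series" means these few. Any claim that something is new, unique, unknown or untested is made for them only; others in the source may bear on it.

Compound 1, `COC(=O)CC1CCN(C[C@H]2CN(c3ccc(-n4cc(-c5ccccn5)cn4)c(F)c3)C(=O)O2)CC1`, gives > 400 ug/mL in an ADME assay on L02 cells (Homo sapiens) for cytotoxicity, read by MTT assay, with a stated time of 48 h (a lower number here means a stronger inhibitor, a higher number a weaker inhibitor), which is a limit of the assay.
Compound 2, `CS(=O)(=O)NC[C@H]1CN(c2ccc(-n3cc(-c4ccccn4)cn3)c(F)c2)C(=O)O1`, gives > 400 ug/mL in this assay, again a limit of the assay.

In this assay compound 2 stands only at a limit, with no number, and (the limit of > 400 ug/mL in this assay, at which 2 of the 2 values shown sit). The measured step that the two limits leave unreadable from compound 1 to compound 2 is therefore unreadable in size. Compound 3, `CNC(=O)[C@H]1CN(c2ccc(-n3cc(-c4ccccn4)cn3)c(F)c2)C(=O)O1`, differs from compound 2 by methylcarbamoyl in place of (methanesulfonamido)methyl on a saturated ring carbon. Among the measured compounds shown here, no measured step bears on this change in readable form, so no step beyond the scatter is expected: the expected step is a number no higher from compound 2 to compound 3 (the limit leaves the size open). Compound 3 is estimated at 400 ug/mL, with a range from 150 ug/mL to 1000 ug/mL, most likely reported again only as a limit.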

Compound 3, half-maximal inhibitory concentration: 217 ug/mL
The estimate for compound 3 lay 1.8-fold (0.27 log units) above the measured number; low and high end bracket the measured number.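

Among the compounds shown here, with methylcarbamoyl on this saturated ring carbon, next to the ring oxygen, compound 3 gives the only actual number in this assay so far. This change gives an at least 1.8-fold lower number from compound 2 to compound 3 (0.26 log units; that floor lies within the scatter), and the wider change gives an at least 1.8-fold lower number from compound 1 to compound 3 (0.26 log units; that floor lies within the scatter). The values of compound 1 and compound 2 remain limits of the assay: the limit of > 400 ug/mL in this assay, at which 2 of the 3 values shown sit.

The true size of both steps remains open, as the compounds shown give only floors for them. Also open, as far as these compounds go, is where the number would fall with a primary amine or a carboxylic acid on this ring carbon.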